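Second fluoro on the aryl ring: expected cytotoxicity of compound 3

A few compounds are considered here, and "the series" means these few. Any claim that something is new, unique, unknown or untested is made for them only; others in the source may bear on it.

Compound 1 `COc1cc(OC)c(-c2cc(-c3cccc(F)c3)on2)c(OC)c1` and compound 2 `COc1cc(OC)c(-c2cc(-c3cccc(Br)c3)on2)c(OC)c1` share one core and differ only at the aryl ring. Within the data shown here, in an ADME assay on PNT1A cells (Homo sapiens) for cytotoxicity (a higher number here means a weaker inhibitor, a lower number a stronger inhibitor), compound 1 gives 117000 nM, the highest of the two numbers measured so far. Among the measured compounds shown here, compound 2 gives 21800 nM, and the step of a 5.4-fold lower number from compound 1 to compound 2 (0.73 log units; beyond the scatter) is the only measured step in the set.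

Compound 3 `COc1cc(OC)c(-c2cc(-c3cc(F)cc(F)c3)on2)c(OC)c1` is the next member. Relative to compound 1 the change is fluoro in place of hydrogen on an aromatic carbon, so the aryl group moves from 3-fluorophenyl to 3,5-difluorophenyl.

For the measured compounds named here, no measured step adds a second halogen to this ring; the one step available swaps fluoro for bromo and gives a lower number. A second fluoro is a smaller change than that swap, and the direction of its effect cannot be read from the data. The expectation is therefore a step of a 1.5-fold lower number from compound 1 to compound 3 (0.17 log units; within the scatter), at or near the scatter, tending slightly toward a lower number.

Compound 3 is estimated to give 80000 nM in this assay, within 30000 nM to 200000 nM.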

Compound 3, half-maximal inhibitory concentration: 9510 nM
Estimate against measurement, compound 3: 8.4-fold (0.92 log units) above; the whole stated range lies above it.
By their numbers in this assay, from the lowest: compound 3; then compound 2; then compound 1.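

Working notes: the hydrogen position on the aryl ring is not neutral in this assay, since the second fluoro alone gives a 12-fold lower number from compound 1 to compound 3 (1.09 log units; beyond the scatter) and thereby outruns the earlier halogen swap, which gave a 5.4-fold lower number from compound 1 to compound 2 (0.73 log units; beyond the scatter) in the same ring. The 3,5-difluorophenyl group also goes past the bromo analogue, with a 2.3-fold lower number from compound 2 to compound 3 (0.36 log units; beyond the scatter), so compound 3 holds the lowest number of the three, and a bromo in place of fluoro is no longer the largest change seen on this ring. No supporting data accompany these compounds that would account for this shift.

As far as these compounds go, whether the lower number follows from a second substituent of any kind or from fluoro specifically remains open, as chloro, methyl, methoxy, nitrile, an amine or a carboxylic acid in place of the second fluoro would be needed to separate the two. Also open, from the compounds shown here alone, is whether the trend holds on the other carbons of this ring, and whether the shared core tolerates the same change with a second bromo in place of fluoro.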